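Replacing cyclohexyl with hex-1-yn-1-yl on the shared core

The compounds below may be only part of what the source reports. "The series", "measured", "known", "first", "only" and "open" are said of these compounds alone.

Two compounds of this series have been examined in a physicochemical assay for solubility, read by HPLC, at pH 7.4; a lower number here means a less soluble compound, a higher number a more soluble compound. Compound 1 `Cc1[nH]c2ccccc2c(=O)c1/C=C/c1cccc([N+](=O)[O-])c1` gives < 2000 nM, which is a limit of the assay and not a number. Going by the values given here, compound 2 `COc1cc2[nH]c(C)c(C3CCCCC3)c(=O)c2cc1Cl` gives 5000 nM, the only actual number available, so it serves as the sole numerical reference point.

Compound 3 `CCCCC#Cc1c(C)[nH]c2cc(OC)c(Cl)cc2c1=O` keeps the core of compound 2 and changes one group. Hex-1-yn-1-yl takes the place of cyclohexyl on an aromatic carbon, ortho to a methyl group (hex-1-yn-1-yl in place of cyclohexyl on an aromatic carbon). Among the compounds with values here, no measured pair shows what such a change does in this assay, so any expectation is anchored only on compound 2 at 5000 nM and is held loosely. A small downward move that stays within the usual scatter of repeated measurements is the likeliest outcome, although a reading that falls to a limit cannot be ruled out. The expected change is a 1.3-fold lower number from compound 2 to compound 3 (0.10 log units; within the scatter). Compound 3 is estimated at 4000 nM, with an expected range from 1500 nM to 11000 nM.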

Compound 3, solubility: > 20000 nM
Compound 3 was reported as a limit; the forecaster's own chance of this, stated with the estimate: 30%; middle value at least 5.0-fold (0.69 log units) from the limit.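

In this assay, hex-1-yn-1-yl in place of cyclohexyl on this aromatic carbon, ortho to a methyl group, gives an at least 4.0-fold higher number from compound 2 to compound 3 (0.60 log units; beyond the scatter), the first step measured at this position in the series and one that lies beyond the scatter. Neither group carries a hydrogen-bond donor, a hydrogen-bond acceptor or a net charge, and both have the same count of heavy atoms, all of them carbon, so the step accompanies a swap of a non-aromatic ring for an open chain with a triple bond, with those counts unchanged. The reading for compound 3 is a limit of the assay and not a number, so the step gives only a minimum and its full size is unknown: the limit of > 20000 nM in this assay, at which 1 of the 3 values shown sits.

The compounds shown cannot separate the loss of the ring from the arrival of the triple bond, and a saturated hexyl chain at this position would be the direct test between the two. Going by these compounds, how a shorter alkyne, or an amine at the end of the chain, would read in this assay also remains open, as does whether this step carries over to any other core.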